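Acid dissociation notes: compound 2 to compound 3

The source may report more compounds than this note shows. Statements on the series, on what has been measured and on what is new or still open speak of the compounds shown alone.

Measured so far in a physicochemical assay for acid dissociation:
- compound 1 `COc1ccc(F)cc1CNCCCNc1ccnc2cc(CC(C)C)ccc12`: 9.47
- compound 2 `COc1ccc(F)cc1CNCCCNc1ccnc2cc(Oc3ccc(C(C)(C)C)cc3)ccc12`: 9.28

The two measured compounds share one core and differ only in the group on the aromatic carbon of that core. Among the compounds with values here, the step of a number 0.19 log units lower from compound 1 to compound 2 (within the scatter) is the only measured step, and it lies within the scatter; compound 2 and compound 1 therefore cannot be told apart on the numbers at hand, and compound 2 stands together with compound 1.

Compound 3 `COc1ccc(F)cc1CNCCCNc1ccnc2cc(Cc3ccccc3)ccc12` is not yet measured. It differs from compound 2 in this way: benzyl in place of 4-(tert-butyl)phenoxy on an aromatic carbon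

Within the data shown here, the one measured step that bears on this change is the exchange at the same aromatic carbon, a number 0.19 log units lower from compound 1 to compound 2 (within the scatter), which was within the scatter. Among the measured compounds shown here, the proton whose dissociation is read is remote from this position in all three compounds, and the single comparison at hand shows no effect of the substituent there. No step beyond the scatter is expected in this assay.

For compound 3 the estimate in this assay is 9.4, with a range of 9.1 to 9.7. This corresponds to an expected step of a number 0.12 log units higher from compound 2 to compound 3 (within the scatter).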

Compound 3, acid dissociation constant: 9.47
Compound 3: the middle estimate sits 0.07 log units below what was measured; the measured number falls inside the stated range.
By their numbers in this assay, from the lowest: compounds 2, 1 and 3 (each within the scatter of the next).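

With the third compound, the position has been read with three groups, and every pair among them can be compared. In this assay benzyl in place of 4-(tert-butyl)phenoxy on the aromatic carbon gives a number 0.19 log units higher from compound 2 to compound 3 (within the scatter) and so adds a second exchange at this place that stays within the scatter, while phenyl in place of isopropyl on the saturated chain carbon bound to that aromatic carbon gives no change at the digits printed from compound 1 to compound 3 (within the scatter) and shows that the two carbon-linked groups cannot be told apart here. Isobutyl, benzyl and 4-(tert-butyl)phenoxy therefore form one group on the numbers, with no compound of the three going against this, and nothing available explains why the read-out stays the same across these groups.

From the compounds shown here alone, all three groups carry no net charge and contain only carbon or carbon and oxygen, so it remains open whether an amine or a carboxylic acid at this aromatic carbon would also stay within the scatter. A nitrile or a trifluoromethyl group at the same place is equally untested by these compounds, and they say nothing about changes elsewhere on the shared core.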